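Hydroxymethyl Added to a Sulfonamide Piperazine Amide

This account rests on a few compounds, and the source may have more. Where it says the series, first, only, none or still open, it means among the compounds named here.

Compound 1, `CC(C(=O)N1CCC(C)(C)CC1)N1CCN(S(=O)(=O)c2ccc(C(C)(C)C)cc2)CC1`: in an ADME assay on HepG2 cells (Homo sapiens) for inhibition, with a stated time of 48 h (on this read-out higher numbers stand for an effect only at larger amounts of compound and lower numbers for an effect already at smaller amounts), compound 1 gives > 40000 nM, which is a limit of the assay.
Compound 2, `CC(C(=O)N1CCc2ccccc21)N1CCN(S(=O)(=O)c2ccc(C(C)(C)C)cc2)CC1`: compound 2 gives > 40000 nM, again a limit.
Compound 3, `CC(C)c1ccc(S(=O)(=O)N2CCN(C(C)C(=O)N3CCCC3)CC2)cc1`: compound 3 gives > 40000 nM, also a limit.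

For the measured compounds named here, the one measured step, a step that the two limits leave unreadable from compound 1 to compound 2, cannot be read because both of its ends sit at the limit of > 40000 nM in this assay, at which 3 of the 3 values shown sit. Compound 3 therefore stands only at this limit, as do the two other values. Compound 4, `CC(C(=O)N1CCCC1)N1CCN(S(=O)(=O)c2ccc(C(C)(C)CO)cc2)CC1`, differs from compound 3 by hydroxymethyl in place of hydrogen on a saturated chain carbon bound to an aromatic carbon and two saturated chain carbons. Going by the values given here, no measured step bears on this change. Compound 4 is expected to remain at the limit, so that a step that the limit leaves unreadable from compound 3 to compound 4 is estimated as no step beyond the scatter. Compound 4 is thus estimated at 60000 nM, within 25000 nM to 200000 nM.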

Compound 4, half-maximal effective concentration: > 40000 nM
Compound 4 was reported as a limit; the forecaster's own chance of this, stated with the estimate: 85%; the middle value is on the limit's open side.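

Compound 3 and compound 4 both sit at a limit, so no step can be read between them: the limit of > 40000 nM in this assay, at which 4 of the 4 values shown sit.

The compounds shown leave open whether hydroxymethyl in place of hydrogen changes the read-out in this assay at all.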